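This account rests on a few compounds, and the source may have more. Where it says the series, first, only, none or still open, it means among the compounds named here.

Measured compounds in this series:

- compound 1 `COc1ccc2ncc(S(=O)(=O)c3ccc(Cl)c(Cl)c3)c(N3CCC(C)CC3)c2c1`: in an assay on isolated protein for displacement of a labelled ligand from metabotropic glutamate receptor 5 (Homo sapiens), with a stated time of 60 min, tested at 1 uM (on this read-out higher numbers stand for more inhibition at the one concentration tested (going by the name of the read-out) and lower numbers for less inhibition), compound 1 gives 87%
- compound 2 `COc1ccc2ncc(S(=O)(=O)c3ccc(Cl)cc3)c(N3CCC(C)CC3)c2c1`: in this assay compound 2 gives 91%
- compound 3 `CC1CCN(c2c(S(=O)(=O)c3cc(F)cc(F)c3)cnc3ccc(Cl)cc23)CC1`: in this assay compound 3 gives 93%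

Compound 3 shows the highest of the three numbers, but the gap to compound 2 and the gap to compound 1 both lie within the scatter, so the three measured compounds cannot be separated on these data.

Compound 4 `COc1ccc2ncc(S(=O)(=O)c3cc(F)cc(F)c3)c(N3CCC(C)CC3)c2c1` has not yet been measured. It differs from compound 3 in one place: methoxy in place of chloro on an aromatic carbon. Compound 4 thus carries the methoxy group found in compounds 1 and 2 together with the difluorophenyl sulfone of compound 3.

For the measured compounds named here, only one measured step exists, a number 4 percentage points higher from compound 1 to compound 2 (within the scatter), and it concerns a change on the other aromatic ring, not the place altered here. Going by the values given here, no measured step covers a methoxy-for-chloro exchange on the shared core. What the data do show is that compounds 1 and 2, both bearing the methoxy group, and compound 3, bearing the chloro, all fall in the same high band within the scatter of one another.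

Compound 4 is therefore expected to stay in that band, with an estimated step of a number 3 percentage points lower from compound 3 to compound 4 (within the scatter), none beyond the scatter. The estimate for compound 4 in this assay is 90%, with a range from 80% to 97%.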

Compound 4, a percentage reported as inhibition, at one concentration (the size of the read-out at that concentration, not a potency): 30%
Compound 4: the middle estimate sits 60 percentage points above what was measured; measured number outside the range, below it.
By their numbers in this assay, from the lowest: compound 4; then compounds 1, 2 and 3 (each within the scatter of the next).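

In this assay, methoxy in place of chloro on this aromatic carbon, meta to a fused ring and para to a fused ring, is not a neutral exchange when the sulfonyl sulfur carries 3,5-difluorophenyl: it gives a number 63 percentage points lower from compound 3 to compound 4 (beyond the scatter). With methoxy held fixed, the sulfonyl side shows the same sensitivity, since 3,5-difluorophenyl in place of 4-chlorophenyl gives a number 61 percentage points lower from compound 2 to compound 4 (beyond the scatter) and 3,5-difluorophenyl in place of 3,4-dichlorophenyl gives a number 57 percentage points lower from compound 1 to compound 4 (beyond the scatter), so methoxy and 3,5-difluorophenyl each occur in compounds with high numbers and the low number appears only in compound 4, which combines them. Nothing available accounts for this dependence between the two places.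

Still open, on these data alone, is whether a hydroxyl, an ethoxy group or an amine on the same aromatic carbon would, alongside 3,5-difluorophenyl, stay with compound 3 or fall with compound 4. Also open, as far as these compounds go, is whether the dependence extends to other sulfonyl aryl groups, such as a pyridyl ring, since the present comparison rests on compound 4 alone.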